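This account rests on a few compounds, and the source may have more. Where it says the series, first, only, none or still open, it means among the compounds named here.

Of the compounds shown here, three have been measured. In a functional assay on A549 cells (Homo sapiens) for antiproliferative activity, read by CCK-8 assay, with a stated time of 72 h (on this read-out lower numbers stand for stronger inhibition and higher numbers for weaker inhibition), compound 1 `Nc1ccccc1NC(=O)/C=C/c1ccc(CSc2ccc(F)cc2)cc1` gives 1190 nM. Compound 3 `Nc1ccccc1NC(=O)/C=C/c1ccc(CSc2cccc3ccccc23)cc1`, which carries naphthalen-1-yl in place of 4-fluorophenyl on a sulfur, gives 830 nM in this assay, so the change a 1.4-fold lower number from compound 1 to compound 3 (0.16 log units; within the scatter) stays within the scatter. Compound 2 `COc1ccc(SCc2ccc(C(=O)Nc3ccccc3N)cc2)cc1` gives 2570 nM in this assay, the highest number of the three; its nearest neighbour is compound 1 and its most distant is compound 3, both of which lie beyond the scatter from it.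

Compound 4 `CCc1ccc(SCc2ccc(C(=O)Nc3ccccc3N)cc2)cc1` differs from compound 2 in one place: ethyl in place of methoxy on an aromatic carbon. Going by the values given here, no measured step changes the group on the aryl ring attached to the sulfur in the way this one does. Among the compounds with values here, the only step that bears on it at all is the exchange of the aryl group on sulfur from compound 1 to compound 3, which is a different kind of change and did not move the number beyond the scatter. On that slim evidence, compound 4 is expected to sit close to compound 2, with a step of a 1.0-fold lower number from compound 2 to compound 4 (0.01 log units; within the scatter) that does not exceed the scatter. Compound 4 is therefore estimated at 2500 nM in this assay, within a range of 1000 nM to 6000 nM.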

Compound 4, half-maximal inhibitory concentration: 3040 nM
Compound 4: middle estimate off by 1.2-fold (0.08 log units), on the low side; low and high end bracket the measured number.
By their numbers in this assay, from the lowest: compounds 3 and 1 (each within the scatter of the next); then compounds 2 and 4 (each within the scatter of the next).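

Going by these compounds alone, the pair gives the first direct reading of a substituent on this ring, at the place para to a large group. In this assay, exchanging methoxy for ethyl, which turns 4-methoxyphenyl into 4-ethylphenyl, gives a 1.2-fold higher number from compound 2 to compound 4 (0.07 log units; within the scatter), so replacing one two-heavy-atom group with another, and one hydrogen-bond acceptor with none, leaves the two numbers indistinguishable in this pair. The data offer no independent measurement that could explain why this step is so small.

The compounds shown leave open whether a group of another kind at this place, such as an amine, a carboxylic acid or a longer chain like n-butyl, would move the number beyond the scatter, since methoxy and ethyl are the only two groups compared here on this core. They also leave open whether the same exchange would behave in the same way on the core of compound 1, or at any other place on this ring.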